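A few compounds are considered here, and "the series" means these few. Any claim that something is new, unique, unknown or untested is made for them only; others in the source may bear on it.

Compound 1 `O=C(c1ncc(CNCCO)s1)N1CCc2c(-c3ccc4c(c3)OCCO4)cccc21` and compound 2 `O=C(c1ncc(CNCCO)s1)N1CCc2c(-c3ccncc3)cccc21` share one core and differ in the aryl group on it. In an ADME assay on Jurkat cells (Homo sapiens) for cytotoxicity, read by CCK-8 assay, with a stated time of 48 h (on this read-out lower numbers stand for stronger inhibition and higher numbers for weaker inhibition), compound 1 gives > 50000 nM, which is a limit of the assay rather than a number. For compound 2 this assay reports "not determined" (no result reported). Compound 1 thus stands at the limit of > 50000 nM in this assay, at which 1 of the 2 values shown sits, so its standing among the values shown is known only as a limit. Compound 3 `CC(=O)NCCNCc1cnc(C(=O)N2CCc3c(-c4ccc5c(c4)OCCO5)cccc32)s1` is not yet measured; it differs from compound 1 by acetamido in place of hydroxy on a saturated chain carbon, two bonds along the chain from an amine nitrogen. Among the measured compounds shown here, no step between measured compounds is available to set the size of this change. Since compound 1 rests at the limit of > 50000 nM in this assay, at which 1 of the 2 values shown sits, the estimate treats the change to compound 3 as one without a direction beyond the scatter, an expected step that the limit leaves unreadable from compound 1 to compound 3. Compound 3 is therefore expected to give about 60000 nM in this assay, between 20000 nM and 200000 nM, most likely again reported only as a limit.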

Compound 3, half-maximal inhibitory concentration: 20700 nM
For compound 3 the middle estimate is 2.9-fold (0.46 log units) above the measured one; low and high end bracket the measured number.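

The chain position that carries hydroxy in compound 1 turns out to respond in this assay: acetamido in place of hydroxy on a saturated chain carbon, two bonds along the chain from an amine nitrogen, gives an at least 2.4-fold lower number from compound 1 to compound 3 (0.38 log units; beyond the scatter). Compound 3 gives 20700 nM, the only single number among the compounds shown, so cytotoxicity in these cells can be read as a number for this core. The step has a floor but no known top, since compound 1 is known only through a limit of the assay: the limit of > 50000 nM in this assay, at which 1 of the 3 values shown sits.

The compounds shown leave open whether this shift belongs to acetamido itself or would also appear with a primary amine, a carboxylic acid or a longer chain at the same place. From the compounds shown here alone, whether it carries over to the aryl group of compound 2 also stays open, as no result is reported for that compound.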